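The compounds below may be only part of what the source reports. "The series", "measured", "known", "first", "only" and "open" are said of these compounds alone.

Measured so far:
compound 1, `COc1cc(/C=C/C(=O)c2cccc(NC(=O)c3ccc(Cl)cc3)c2)ccc1O`: 42%
compound 2, `COc1cc(/C=C/C(=O)c2cccc(NC(=O)C(C)C)c2)ccc1O`: 51%

For the measured compounds named here, compound 1 stands lowest of the two numbers in a functional assay on HUVEC cells (Homo sapiens) for inhibition, tested at 5 ug/mL (a lower number here means a weaker effect, a higher number a stronger effect of the compound at the concentration tested), the only step away from it, a number 9 percentage points higher from compound 1 to compound 2 (within the scatter), lying within the scatter. The unmeasured compound 3, `COc1cc(/C=C/C(=O)c2cccc(NC(=O)c3ccccc3)c2)ccc1O`, differs from compound 1 by hydrogen in place of chloro on an aromatic carbon. Going by the values given here, one measured step bears on this site: a number 9 percentage points higher from compound 1 to compound 2 (within the scatter) exchanges the whole 4-chlorophenyl for isopropyl on the carbonyl carbon and still stays within the scatter. The change to compound 3 keeps the phenyl and removes only the chloro, a smaller alteration than that swap. With both measured values close together, nothing in the two numbers points to a shift beyond the scatter in either direction. Compound 3 is therefore expected close to compound 1, a number 3 percentage points higher from compound 1 to compound 3 (within the scatter). The estimate for compound 3 is 45%, with a range from 30% to 60%.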

Compound 3, a percentage reported as inhibition, at one concentration (the size of the read-out at that concentration, not a potency): 48%
Compound 3: middle estimate off by 3 percentage points, on the low side, and the stated range covers the measured number.
By their numbers in this assay, from the lowest: compounds 1, 3 and 2 (each within the scatter of the next).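

In this assay, the step from chloro to hydrogen on the aromatic carbon keeps the benzoyl and isolates the chloro, which the earlier exchange of the whole 4-chlorophenyl for isopropyl could not do: a number 6 percentage points higher from compound 1 to compound 3 (within the scatter). The second new step, a number 3 percentage points lower from compound 2 to compound 3 (within the scatter), compares phenyl with isopropyl on the carbonyl carbon without the chloro, and so all three acyl variants now lie within the scatter of their neighbours at this single concentration. No available measurement accounts for these small steps.

From the compounds shown here alone, whether a methoxy, an amine or a carboxylic acid on the same aromatic carbon would move the number beyond the scatter remains open. So does the effect of a longer chain in place of isopropyl on the carbonyl carbon.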